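The source may hold more compounds than are shown below. What is called first, only, known or untested is meant among the compounds shown, and "the series" means these compounds.

Compound 1 `CC1=CC[C@H](C(C)(C)NC(=S)N/N=C/c2ccc(O)cc2)CC1` gives > 100000 nM in an ADME assay on Vero cells (Chlorocebus sabaeus) for inhibition, read by sulforhodamine B assay, with a stated time of 48 h (a higher number here means a weaker inhibitor of growth, a lower number a stronger inhibitor of growth), which is a limit rather than a number.
Compound 2 `CC1=CC[C@H](C(C)(C)NC(=S)N/N=C/c2ccc(N(C)C)cc2)CC1` gives > 100000 nM in this assay, again a limit.
Compound 3 `COc1cc(/C=N/NC(=S)NC(C)(C)[C@H]2CC=C(C)CC2)ccc1O` gives 91800 nM in this assay.

Compound 1 therefore stands at the limit of this assay, with no number of its own; two of the three values shown share that position, as stated by the limit of > 100000 nM in this assay, at which 2 of the 3 values shown sit. The steps measured from it tell little. From compound 1 to compound 2 the change is a step that the two limits leave unreadable from compound 1 to compound 2, so no size can be read. From compound 1 to compound 3 the change is an at least 1.0-fold lower number from compound 1 to compound 3 (0.03 log units; that floor lies within the scatter), and that floor lies within the scatter of repeated measurement.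

Compound 4 `CC1=CC[C@H](C(C)(C)NC(=S)N/N=C/c2ccco2)CC1` differs from compound 1 in one place: furan-2-yl in place of 4-hydroxyphenyl on a carbon with a double bond to nitrogen. Neither measured step involves this part of the molecule in the same way, and both leave the size of any shift unreadable or within the scatter. Compound 4 is therefore expected to sit close to where compound 1 sits, with no step beyond the scatter foreseen, so that a number no higher from compound 1 to compound 4 (the limit leaves the size open) is the estimated change. In this assay compound 4 is expected to give about 100000 nM, within a range from 45000 nM to 220000 nM, with a fair chance that only a limit is reported.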

Compound 4, concentration for total growth inhibition: 14700 nM
Compound 4: middle estimate off by 6.8-fold (0.83 log units), on the high side, outside the stated range (below it).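

In this assay, this place on the molecule turns out to respond to change: furan-2-yl in place of 4-hydroxyphenyl on a carbon with a double bond to nitrogen gives an at least 6.8-fold lower number from compound 1 to compound 4 (0.83 log units; beyond the scatter). The earlier changes, all made on the six-membered aromatic ring, had shown no shift beyond the scatter, since one step could not be read and the floor of the other lay within the scatter, so this is the first sign that replacing the ring itself can yield a stronger inhibitor of growth. The true size of the step remains unknown because compound 1 carries only a limit and no number of its own: the limit of > 100000 nM in this assay, at which 2 of the 4 values shown sit.

The change replaces a six-membered aromatic ring of carbon only with a five-membered aromatic ring with a hetero atom and also removes the hydrogen-bond donor, and the compounds shown do not separate these differences. From the compounds shown here alone, whether an unsubstituted phenyl, a thiophen-2-yl or a pyridin-2-yl group at this place would give a number near that of compound 4 remains open.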